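A Methyl on the Phenyl of Compound 3

A few compounds are considered here, and "the series" means these few. Any claim that something is new, unique, unknown or untested is made for them only; others in the source may bear on it.

Compound 1 `COc1cc2c(Oc3ccc(NC(=O)c4nn(-c5ccccc5)cc(C)c4=O)cc3F)ccnc2cc1OCCCCCC(=O)NO`: in a functional assay on HCT-116 cells (Homo sapiens) for inhibition, read by MTT assay, with a stated time of 72 h (on this read-out higher numbers stand for weaker inhibition and lower numbers for stronger inhibition), compound 1 gives 690 nM.
Compound 2 `COc1cc2c(Oc3ccc(NC(=O)c4nn(-c5ccccc5)ccc4=O)cc3)ccnc2cc1OCCCC(=O)NO`: in this assay compound 2 gives 940 nM.
Compound 3 `COc1cc2c(Oc3ccc(NC(=O)c4nn(-c5ccccc5)cc(C)c4=O)cc3)ccnc2cc1OCCCCCCC(=O)NO`: in this assay compound 3 gives 150 nM.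

Among these three, compound 3 stands with the lowest number, and its distance from both compound 1 and compound 2 lies beyond the usual scatter, so it is the strongest inhibitor of the measured set. The unmeasured compound 4 `COc1cc2c(Oc3ccc(NC(=O)c4nn(-c5ccccc5C)cc(C)c4=O)cc3)ccnc2cc1OCCCCCCC(=O)NO` differs from compound 3 only in one place: methyl in place of hydrogen on an aromatic carbon. Among the compounds with values here, no measured pair here shows this change, so nothing in the data tells its size. The step from compound 3 to compound 4 is expected to stay within the scatter, a 1.3-fold higher number from compound 3 to compound 4 (0.12 log units; within the scatter). Compound 4 is therefore estimated at 200 nM, with a range from 70 nM to 600 nM.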

Compound 4, half-maximal inhibitory concentration: 660 nM
For compound 4 the middle estimate is 3.3-fold (0.52 log units) below the measured one, and the stated range ends below it.
By their numbers in this assay, from the lowest: compound 3; then compounds 4, 1 and 2 (each within the scatter of the next).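

Within the data shown here, the one matched pair shows that this position on the phenyl does not tolerate every change: in this assay, 2-methylphenyl in place of phenyl gives a 4.4-fold higher number from compound 3 to compound 4 (0.64 log units; beyond the scatter), a modest but real loss of inhibition. A single added carbon, ortho to a large group, is thus enough to move the number beyond the scatter. Nothing available accounts for this result. Still open, on these data alone, is whether a fluorine or a methoxy on the same carbon would act like methyl, and whether methyl on another carbon of the phenyl would give the same step.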